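Bicyclic heteroaryl amide swap in a sulfonylbenzyl series

The source may hold more compounds than are shown below. What is called first, only, known or untested is meant among the compounds shown, and "the series" means these compounds.

Of the compounds shown here, two have numbers so far. Compound 1 `O=C(NCc1ccc(S(=O)(=O)c2ccccc2)cc1)c1nc2ccncc2s1` is measured in an ADME assay on microsomes from liver (Homo sapiens) for metabolic stability, read by LC-MS, with a stated time of 30 min, tested at 1 uM (a higher number here means that more of the compound is left, a lower number that less of the compound is left), and gives 68%. Compound 2 `CC(NC(=O)c1cc2cnccc2[nH]1)c1ccc(S(=O)(=O)N2CCCCC2)cc1` gives 34% in this assay. For the measured compounds named here, of the two, compound 1 stands higher, and the gap to compound 2 lies beyond the usual scatter; no single-point step between the two is available, so only the two values themselves can be compared.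

Compound 3 `O=C(NCc1ccc(S(=O)(=O)c2ccccc2)cc1)c1cnc2nccn2c1` has not yet been measured. It differs from compound 1 in one place: a group of 9 heavy atoms (6 carbon, 3 nitrogen; one five-membered aromatic ring with 2 hetero atoms, one six-membered aromatic ring with 2 hetero atoms) in place of a group of 9 heavy atoms (6 carbon, 2 nitrogen, 1 sulfur; one five-membered aromatic ring with 2 hetero atoms, one six-membered aromatic ring with 1 hetero atom), on a carbonyl carbon The rest of the molecule, including the sulfonylbenzyl amide portion, is unchanged.

Going by the values given here, no step between measured compounds informs this particular exchange, so the expectation rests on compound 1 alone. Given that compound 1 reaches 68% in this assay, compound 3 is expected to land near the same level, with the step of a number 3 percentage points lower from compound 1 to compound 3 (within the scatter) estimated to stay within the usual scatter rather than move clearly in either direction. The estimate for compound 3 in this assay is 65%, with a range from 45% to 85%.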

Compound 3, percent of the compound remaining: 60%
Estimate against measurement, compound 3: 5 percentage points above; the range from low to high includes it.
By their numbers in this assay, from the lowest: compound 2; then compounds 3 and 1 (each within the scatter of the next).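

In this assay, for the compounds shown here, the first single-place step reads a number 8 percentage points lower from compound 1 to compound 3 (within the scatter), so compound 1 and compound 3 cannot be told apart in this read-out. On this carbonyl carbon, then, the group of 6 carbon and 3 nitrogen atoms stands in for the group of 6 carbon, 2 nitrogen and 1 sulfur atoms without a difference beyond the scatter, although sulfur leaves and the six-membered aromatic ring gains a hetero atom, while the counted hydrogen-bond donors and acceptors stay the same. Nothing measured here speaks to why the two groups read alike.

Going by these compounds alone, this single pair shows only that these two bicyclic groups read alike on the sulfonylbenzyl amide of compound 1, and it leaves open whether a plain phenyl group or a group carrying a dimethylamino substituent on the same carbonyl carbon would do the same. Also open is whether the same exchange would read alike with the different sulfonyl portion and the extra methyl-bearing amide side of compound 2, which has no single-place partner among the compounds shown.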